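The source may report more compounds than this note shows. Statements on the series, on what has been measured and on what is new or still open speak of the compounds shown alone.

Going by the values given here, compound 2 `Cc1cc(-c2cccc(C#N)c2)cc(C)c1Nc1ccnc(Nc2ccc(C#N)cc2)n1` gives 920 nM in an ADME assay on MT4 cells (Homo sapiens) for cytotoxicity, read by MTT assay, with a stated time of 4 days (a lower number here means that less compound is tolerated, a higher number that more compound is tolerated), the lowest of the three numbers measured so far. Compound 1 `COc1ccc(-c2cc(C)c(Nc3ccnc(Nc4ccc(C#N)cc4)n3)c(C)c2)cc1` gives 2890 nM in this assay, and compound 3 `Cc1cc(-c2cccc(F)c2)cc(C)c1Nc1ccnc(Nc2ccc(C#N)cc2)n1` gives 4120 nM; the steps are a 3.1-fold lower number from compound 1 to compound 2 (0.50 log units; beyond the scatter) and a 4.5-fold higher number from compound 2 to compound 3 (0.65 log units; beyond the scatter), while the step of a 1.4-fold higher number from compound 1 to compound 3 (0.15 log units; within the scatter) is within the scatter.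

Compound 4 `Cc1cccc(-c2cc(C)c(Nc3ccnc(Nc4ccc(C#N)cc4)n3)c(C)c2)c1` differs from compound 2 by methyl in place of cyano on an aromatic carbon. Among the compounds with values here, the step that bears on this is the one from compound 2 to compound 3, where a 4.5-fold higher number from compound 2 to compound 3 (0.65 log units; beyond the scatter) when the cyano was exchanged; the exchange of the 3-cyanophenyl for 4-methoxyphenyl, read backwards from a 3.1-fold lower number from compound 1 to compound 2 (0.50 log units; beyond the scatter), points the same way. Both replacements of the cyano raised the number, so a rise beyond the scatter is expected for compound 4 as well, with a 3.3-fold higher number from compound 2 to compound 4 (0.51 log units; beyond the scatter) as the estimated step. Compound 4 is therefore expected to give about 3000 nM in this assay, within a range of 1200 nM to 7500 nM.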

Compound 4, half-maximal cytotoxic concentration: 3670 nM
Compound 4: middle estimate off by 1.2-fold (0.09 log units), on the low side, within the range that was stated.
By their numbers in this assay, from the lowest: compound 2; then compounds 1, 4 and 3 (each within the scatter of the next).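

In this assay the change from cyano to methyl gives a 4.0-fold higher number from compound 2 to compound 4 (0.60 log units; beyond the scatter) and so sets the low number of compound 2 against a second replacement at this place, after fluoro. Fluoro and methyl are not told apart here, with a 1.1-fold lower number from compound 3 to compound 4 (0.05 log units; within the scatter) as the step between them, and the exchange of 4-methoxyphenyl for 3-methylphenyl, a 1.3-fold higher number from compound 1 to compound 4 (0.10 log units; within the scatter) as its step, also stays within the scatter. Of the four compounds, only compound 2 with its 3-cyanophenyl stands apart, while compounds 1, 3 and 4 lie within the scatter of one another.

From the compounds shown here alone, whether an amine or a carboxylic acid at this place would stay with compounds 3 and 4 or go with compound 2 remains open. Nothing given here accounts for the lower number of compound 2.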